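The source may report more compounds than this note shows. Statements on the series, on what has been measured and on what is new or still open speak of the compounds shown alone.

Of the compounds shown here, three with a shared core have been measured in a functional assay on QGY7701 cells (Homo sapiens) for cytotoxicity, read by MTT assay, with a stated time of 24 h; on this read-out lower numbers stand for stronger inhibition and higher numbers for weaker inhibition. Compound 1 `C=CC1=C(C(=O)NCc2ccc(C)cc2)C(c2ccc(F)cc2)OC1` gives 62100 nM in this assay. Compound 2 `C=CC1=C(C(=O)NCc2ccc(Cl)cc2)C(c2ccc(F)cc2)OC1` differs from compound 1 by chloro in place of methyl on an aromatic carbon. In this assay compound 2 gives 36900 nM; the step is a 1.7-fold lower number from compound 1 to compound 2 (0.23 log units; within the scatter). Compound 3 `C=CC1=C(C(=O)NCc2ccc(C)cc2)C(c2ccc(OC)c(OC)c2)OC1` carries another core; the difference between the two cores is not broken down here. In this assay compound 3 gives 69100 nM, a number that sits within the scatter of the values of compound 1 and compound 2.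

Compound 4 `C=CC1=C(C(=O)NCc2ccc(Cl)cc2)C(c2ccc(OC)c(OC)c2)OC1` has not yet been measured. It differs from compound 3 by chloro in place of methyl on an aromatic carbon, the same change that separates compound 1 and compound 2, at the same place on the ring. The step expected from this change in this assay is a 1.6-fold lower number from compound 3 to compound 4 (0.22 log units; within the scatter), which rests on the measured step of a 1.7-fold lower number from compound 1 to compound 2 (0.23 log units; within the scatter) and is taken to be of a similar, modest size. Compound 4 is therefore estimated to give 42000 nM in this assay, with a likely range from 20000 nM to 90000 nM.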

Compound 4, half-maximal inhibitory concentration: > 100000 nM
Compound 4 was reported as a limit; the forecaster's own chance of this, stated with the estimate: 10%; middle value at least 2.3-fold (0.37 log units) from the limit.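

In this assay compound 4 gives > 100000 nM, which is a limit of the assay and not a number. Measured against compound 3, the change from 4-methylbenzyl to 4-chlorobenzyl can therefore be given only as a floor: an at least 1.4-fold higher number from compound 3 to compound 4 (0.16 log units; that floor lies within the scatter). This does not show that the change behaves differently on the two cores, nor does it show that the change carries across them, and the two steps can only be set side by side: the same change on two cores in this assay, a 1.7-fold lower number (0.23 log units; within the scatter) from compound 1 to compound 2 and an at least 1.4-fold higher number (0.16 log units; that floor lies within the scatter) from compound 3 to compound 4; the limit leaves it open whether they differ

The compounds shown leave open how large the step on the core of compound 3 really is, since only one side of it is a number. They also leave open whether a bromo, a nitrile or a carboxylic acid in place of the methyl would follow the same course on both cores, as each core here carries only the methyl and chloro pair.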